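This account rests on a few compounds, and the source may have more. Where it says the series, first, only, none or still open, it means among the compounds named here.

Compound 1 `Cn1c(-c2ccc(C(=O)NC3CC3)cc2)nnc1C1(c2ccc(Cl)cc2)CCC1`: > 4000 nM; compound 2 `Cn1c(-c2ccc(-c3cnccn3)cc2F)nnc1C1(c2ccc(Cl)cc2)CCC1`: > 4000 nM.

In an assay on isolated protein for inhibition of 11-beta-hydroxysteroid dehydrogenase type 2 (Mus musculus) (on this read-out higher numbers stand for weaker inhibition and lower numbers for stronger inhibition), compound 1 reaches only a limit, > 4000 nM. Compound 2 likewise stops at a limit in this assay, > 4000 nM. Compound 1 thus stands at the limit of > 4000 nM in this assay, at which 2 of the 2 values shown sit, with no number of its own. Compound 3 `Cc1noc(C)c1-c1ccc(-c2nnc(C3(c4ccc(Cl)cc4)CCC3)n2C)cc1` arises from compound 1 by 3,5-dimethyl-1,2-oxazol-4-yl in place of cyclopropylcarbamoyl on an aromatic carbon. For the measured compounds named here, no measured pair covers this change, so the step is expected to stay within the scatter, with no direction, at a step that the limit leaves unreadable from compound 1 to compound 3. Compound 3 is therefore estimated at 6000 nM, within 2000 nM to 20000 nM, most probably again reported as a limit.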

Compound 3, half-maximal inhibitory concentration: > 4000 nM
Compound 3: a limit, no number (the forecaster's own chance of this, stated with the estimate: 75%); the middle value does not contradict the limit.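

For the compounds shown here, compound 3 stops at > 4000 nM as a limit, so no step from compound 1 to compound 3 can be read. The compounds shown leave open how strongly any of them inhibits in this assay: the limit of > 4000 nM in this assay, at which 3 of the 3 values shown sit.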